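Replacing 4-methylpiperazin-1-yl in compound 2

The compounds below may be only part of what the source reports. "The series", "measured", "known", "first", "only" and "open" are said of these compounds alone.

In a physicochemical assay for solubility (a lower number here means a less soluble compound, a higher number a more soluble compound), compound 1 (`O=S(=O)(Nc1ncccn1)c1ccc2c(c1)OCC[C@@H]2c1ccc(C(F)(F)F)cc1-c1ccc(F)nc1`) gives 408000 nM, compound 2 (`CN1CCN(c2cc(C(F)(F)F)ccc2[C@H]2CCOc3cc(S(=O)(=O)Nc4nccs4)ccc32)CC1`) gives 176000 nM and compound 3 (`Cn1nccc1-c1cc(C(F)(F)F)ccc1[C@@H]1CCOc2cc(S(=O)(=O)Nc3nccs3)ccc21`) gives 65000 nM. Compound 2 is thus second highest of the three, and its gaps to the other two lie beyond the scatter. Compound 4 (`Cc1nc(-c2cc(C(F)(F)F)ccc2[C@H]2CCOc3cc(S(=O)(=O)Nc4nccs4)ccc32)co1`) has 2-methyl-1,3-oxazol-4-yl in place of 4-methylpiperazin-1-yl on an aromatic carbon. Among the measured compounds shown here, no measured step isolates this change. The nearest guide is compound 3, at 65000 nM, which also carries a five-membered aromatic ring there. A fall beyond the scatter is expected, with the estimated step of a 2.9-fold lower number from compound 2 to compound 4 (0.47 log units; beyond the scatter). For compound 4 the estimated value is 60000 nM, with an expected range of 20000 nM to 170000 nM.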

Compound 4, solubility: 61000 nM
The estimate for compound 4 lay 1.0-fold (0.01 log units) below the measured number, and the stated range covers the measured number.
By their numbers in this assay, from the lowest: compounds 4 and 3 (each within the scatter of the next); then compound 2; then compound 1.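

In this assay, among the compounds shown here, the change from 4-methylpiperazin-1-yl to 2-methyl-1,3-oxazol-4-yl reads a 2.9-fold lower number from compound 2 to compound 4 (0.46 log units; beyond the scatter) at this aromatic carbon, the only step isolated at this position so far. Compound 4 at 61000 nM and compound 3 at 65000 nM stand within the scatter of each other, so these two five-membered aromatic rings give matching numbers here. Nothing on hand accounts for the step.

Open, on these data alone, is where a non-aromatic ring without the methyl group, such as piperidine or morpholine, or an open-chain dimethylamino group would fall at this aromatic carbon. Also open, as far as these compounds go, is how a carboxylic acid there would compare with these values.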